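Trimming the anilide to a bare amide in an orexin-1 series

A few compounds are considered here, and "the series" means these few. Any claim that something is new, unique, unknown or untested is made for them only; others in the source may bear on it.

Measured so far:
compound 1 `Cc1occc1-c1nnc(SCC(=O)Nc2ccc(F)c(Cl)c2)n1Cc1ccco1` gives 1000 nM in a functional assay on CHO cells for antagonist activity at Orexin/Hypocretin receptor type 1 (Homo sapiens), read by FLIPR and calcium flux; a higher number here means a weaker inhibitor, a lower number a stronger inhibitor
compound 2 `Cc1occc1-c1nnc(SCC(=O)Nc2ccc(N(C)C)cc2)n1Cc1ccco1` gives 794 nM in this assay

Compound 2 stands lowest of the two numbers, but only by a 1.3-fold lower number from compound 1 to compound 2 (0.10 log units; within the scatter). Compound 3 `Cc1occc1-c1nnc(SCC(N)=O)n1Cc1ccco1` differs from compound 2 by hydrogen in place of 4-(dimethylamino)phenyl on an amide-type nitrogen. Among the measured compounds shown here, the one measured step swaps substituents on that ring and stays within the scatter; none tests removing the ring itself. Since the group leaving is the larger part of the molecule at that end, compound 3 is expected to give a clearly higher number, a 10-fold higher number from compound 2 to compound 3 (1.00 log units; beyond the scatter). The estimate for compound 3 is 8000 nM, between 2000 nM and 30000 nM.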

Compound 3, inhibition constant: > 15800 nM
Compound 3 gave a limit, no number; the forecaster's own chance of this, stated with the estimate: 40%; at least 1.9-fold (0.29 log units) between middle value and limit.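

In this assay compound 3 gives a limit of the assay, not a number: > 15800 nM. Compound 1 and compound 2 lie within the scatter of each other despite carrying different ring substituents, but removing the whole ring from the amide nitrogen has a large effect, with an at least 19-fold higher number from compound 2 to compound 3 (1.29 log units; beyond the scatter) and an at least 15-fold higher number from compound 1 to compound 3 (1.19 log units; beyond the scatter). So this position tolerated both substituted rings shown, yet a bare amide falls far behind either. Still open, on these data alone, is whether an aromatic ring is needed there or any carbon group would do: a methyl, cyclohexyl or benzyl group on that nitrogen would separate the two.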